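This account rests on a few compounds, and the source may have more. Where it says the series, first, only, none or still open, it means among the compounds named here.

Compound 1 `C=CCn1c(=O)/c(=C\c2cccc(Cl)c2)[nH]c(=O)/c1=C\c1ccccc1OC` — 8900 nM
Compound 2 `COc1ccccc1/C=c1/[nH]c(=O)/c(=C\c2ccccc2OC)n(C)c1=O` — "not active" (no number reported)
Compound 3 `COc1ccccc1/C=c1/[nH]c(=O)/c(=C\c2cccc(Cl)c2Cl)[nH]c1=O` — "not active" (no number reported)

Three compounds built on one shared core were tested in a functional assay on Huh-7 cells (Homo sapiens) for cytotoxicity, read by CCK-8 assay, with a stated time of 72 h; on this read-out higher numbers stand for weaker inhibition and lower numbers for stronger inhibition. Compound 1 is the only one of the three that returned a number, giving 8900 nM. Compound 2 came back as "not active" (no number reported). Compound 3 likewise came back as "not active" (no number reported). Going by the values given here, with no number for either of them, nothing can be said about how far compound 2 or compound 3 stands from compound 1, only that compound 1 alone showed measurable inhibition.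

Compound 4 `C=CCn1c(=O)/c(=C\c2cccc(F)c2)[nH]c(=O)/c1=C\c1ccccc1OC` has not yet been measured. It differs from compound 1 in a single place: fluoro in place of chloro on an aromatic carbon. Among the compounds with values here, no pair of measured compounds differs in just one place, so there is no measured step of this kind to lean on. A halogen swap of this sort usually moves activity only a little, and the direction here is guessed rather than known; a mild weakening is expected, close to the scatter. Given that two of the three measured compounds returned no number, a result with no number for compound 4 is also quite possible. In this assay compound 4 is expected to give 15000 nM, with a likely range from 6000 nM to 40000 nM. The expected step of a 1.7-fold higher number from compound 1 to compound 4 (0.23 log units; within the scatter) is small.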

Compound 4, half-maximal inhibitory concentration: 27200 nM
Compound 4: the middle estimate sits 1.8-fold (0.26 log units) below what was measured; the measured number falls inside the stated range.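

In this assay, going by these compounds alone, fluoro in place of chloro on this aromatic carbon gives a 3.1-fold higher number from compound 1 to compound 4 (0.49 log units; beyond the scatter), the first step on this shared core that can be read from a single change. The swap is therefore not silent: this position responds to which halogen sits on it, with the chloro compound giving the lower number, though the 3-fluorophenyl compound still returns a number. Nothing measured in the data shown explains why the number moves in this direction.

On these data alone, two halogens say little about the position as a whole, so it remains open how a bromo group, a nitrile or an amine on the same carbon would read. It is also unclear whether the same swap would give a similar step if the allyl chain were replaced by a methyl group.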